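A fluorine added to the 2-phenylethenyl group of compound 3

The source may hold more compounds than are shown below. What is called first, only, known or untested is meant among the compounds shown, and "the series" means these compounds.

Compound 1, `CC(=O)c1cc(-c2ccc(F)cc2)cc2cc(-c3ccc(F)cc3)[nH]c12`, gives 87400 nM in a functional assay on MCF7 cells (Homo sapiens) for cytotoxicity, read by MTT assay, with a stated time of 2 days; a higher number here means that more compound is tolerated, a lower number that less compound is tolerated.
Compound 2, `COc1ccc(-c2cc(C(C)=O)c3[nH]c(-c4ccc(F)cc4)cc3c2)cc1`, gives 16800 nM in this assay.
Compound 3, `CC(=O)c1cc(/C=C/c2ccccc2)cc2cc(-c3ccc(F)cc3)[nH]c12`, reaches only a limit of > 100000 nM in this assay; this is a limit, not a number.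

Compound 3 therefore sits at the top of the measured range, at the limit of > 100000 nM in this assay, at which 1 of the 3 values shown sits. The step from compound 1 was an at least 1.1-fold higher number from compound 1 to compound 3 (0.05 log units; that floor lies within the scatter), and that from compound 2 was an at least 5.9-fold higher number from compound 2 to compound 3 (0.77 log units; beyond the scatter). Compound 4, `CC(=O)c1cc(/C=C/c2ccc(F)cc2)cc2cc(-c3ccc(F)cc3)[nH]c12`, differs from compound 3 by fluoro in place of hydrogen on an aromatic carbon. Within the data shown here, no measured step tests this exact change, and a single fluorine is a small alteration, so no step beyond the scatter is expected in this assay. Compound 4 is expected to give about 110000 nM (between 50000 nM and 250000 nM), meaning an expected step that the limit leaves unreadable from compound 3 to compound 4, most likely again reported only as a limit.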

Compound 4, concentration lethal to 50% of the cells: > 100000 nM
Compound 4 gave a limit, no number; the forecaster's own chance of this, stated with the estimate: 60%; the middle value lies beyond the limit too.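

With fluoro on the ring, the 2-(4-fluorophenyl)ethenyl group of compound 4 still gives only a limit in this assay, as the 2-phenylethenyl group of compound 3 does: the limit of > 100000 nM in this assay, at which 2 of the 4 values shown sit.

Any step between compound 3 and compound 4 cannot be read. Putting this group in place of 4-methoxyphenyl gives an at least 5.9-fold higher number from compound 2 to compound 4 (0.77 log units; beyond the scatter), and putting it in place of 4-fluorophenyl gives an at least 1.1-fold higher number from compound 1 to compound 4 (0.05 log units; that floor lies within the scatter).

Going by these compounds, whether an amine or a carboxylic acid at this place on the ring would give a number rather than a limit stays open.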